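From thiophen-3-yl to pyridin-4-yl on the shared core

The source may hold more compounds than are shown below. What is called first, only, known or untested is meant among the compounds shown, and "the series" means these compounds.

Three compounds measured in a functional assay on MDA-MB-231 cells (Homo sapiens) for cytotoxicity, read by ELISA, with a stated time of 2 days; a lower number here means a stronger inhibitor, a higher number a weaker inhibitor
Compound 1 `Oc1cccc(-c2cc(-c3ccccc3)cc(-c3ccsc3)n2)c1` gives 12100 nM
Compound 2 `Oc1ccc(-c2cc(-c3ccccc3)cc(-c3ccc(O)cc3)n2)cc1` gives 6700 nM
Compound 3 `Oc1cccc(-c2cc(-c3ccccc3)nc(-c3ccsc3)c2)c1` gives 19000 nM

Compound 3 lies within the scatter of compound 1 in this assay and its number is higher than that of compound 2, a gap beyond the scatter. Compound 4 `Oc1cccc(-c2cc(-c3ccccc3)nc(-c3ccncc3)c2)c1` carries pyridin-4-yl in place of thiophen-3-yl on an aromatic carbon next to the ring nitrogen pyridin-4-yl in place of thiophen-3-yl on an aromatic carbon and awaits measurement. Among the compounds with values here, no measured pair differs in one place, so the data offer no direct precedent for this change. With nothing pointing either way, no shift beyond the scatter is expected, and the estimated step of a 1.3-fold lower number from compound 3 to compound 4 (0.10 log units; within the scatter) has no firm direction. The value expected for compound 4 is 15000 nM within a range from 6000 nM to 40000 nM as estimated here.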

Compound 4, half-maximal inhibitory concentration: 12200 nM
Estimate against measurement, compound 4: 1.2-fold (0.09 log units) above; the range from low to high includes it.
By their numbers in this assay, from the lowest: compounds 2, 1, 4 and 3 (each within the scatter of the next, the first and the last beyond it).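

In this assay the first pair differing in one place gives a 1.6-fold lower number from compound 3 to compound 4 (0.19 log units; within the scatter) and so shows that, on this aromatic carbon next to the ring nitrogen, pyridin-4-yl can replace thiophen-3-yl without a shift beyond the scatter. A six-membered aromatic ring is therefore tolerated here as well as a five-membered one, at least in this single pair. No available evidence bears on this result. The compounds shown leave open whether an amine, a carboxylic acid or a morpholine ring at this place would give a shift beyond the scatter. From the compounds shown here alone, whether pyridin-3-yl would match pyridin-4-yl also remains open.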